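A few compounds are considered here, and "the series" means these few. Any claim that something is new, unique, unknown or untested is made for them only; others in the source may bear on it.

Three related chain compounds have been tested so far in a functional assay on Coronary artery (Bos taurus) (on this read-out higher numbers stand for an effect only at larger amounts of compound and lower numbers for an effect already at smaller amounts), and give numbers to compare. There compound 1 (`CCCCNC(=O)C(=O)NCCCC/C=C\CCCCCCC(=O)OCCOCCOCCO`) gives 1500 nM in this test, and compound 3 (`CCCCNC(=O)C(=O)NCCCC/C=C\CCCCCCc1nnn[nH]1`) gives 1700 nM in the same test. Compound 2 (`CCCCCNC(=O)NCCCC/C=C\CCCCCS(=O)(=O)c1ccccc1O`) gives 5000 nM as the highest of the three numbers, beyond the usual scatter from both of the others, so it needs the largest amount of compound to reach its half-maximal effect.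

Compound 4 (`CCCCCNC(=O)NCCCC/C=C\CCCCCCC1=NOS(=O)N1`) has not been measured yet. The change from compound 2 is a group of 7 heavy atoms (2 carbon, 2 nitrogen, 2 oxygen, 1 sulfur; one five-membered non-aromatic ring with 4 hetero atoms) in place of a group of 10 heavy atoms (6 carbon, 3 oxygen, 1 sulfur; one six-membered aromatic ring of carbon only), on a saturated chain carbon, five bonds along the chain from a double-bonded chain carbon and the rest of the structure stays the same. Among the compounds with values here, no measured pair shows this exchange on its own, so any expectation rests on thin ground. The closest guide is compound 3 at 1700 nM as it also ends its chain in a small ring that holds hetero atoms, although compound 3 differs from compound 4 elsewhere in the structure too.

The expected change is a modest one toward a lower number, an estimated 2.0-fold lower number from compound 2 to compound 4 (0.30 log units; within the scatter) that lies near the edge of the scatter. For compound 4 the estimated value is 2500 nM with an expected range from 700 nM to 9000 nM for repeated measurements.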

Compound 4, half-maximal effective concentration: 340 nM
The estimate for compound 4 lay 7.4-fold (0.87 log units) above the measured number, outside the stated range (below it).
By their numbers in this assay, from the lowest: compound 4; then compounds 1 and 3 (each within the scatter of the next); then compound 2.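

In this assay, within the data shown here, replacing the (2-hydroxyphenyl)sulfonyl group with the five-membered non-aromatic ring with 4 hetero atoms, on a saturated chain carbon five bonds along the chain from a double-bonded chain carbon, gives a 15-fold lower number from compound 2 to compound 4 (1.17 log units; beyond the scatter) and provides the first direct evidence that the group at this place strongly affects the read-out. The counts of hydrogen-bond donors and acceptors stay the same, there is no net charge on either group, and the entering group has fewer heavy atoms, so these counts do not track the large step and a bulkier aromatic group is not needed here for an effect at smaller amounts. No measurement shown here explains why this exchange has such a large effect.

A single exchange cannot show which part of the new ring matters, or whether a simpler carboxylic acid or a tetrazole at this same place, with the rest of compound 4 unchanged, would give a similar number. It also leaves open whether the hydroxyl on the benzene ring of compound 2 contributes to that compound's higher number, which a plain phenylsulfonyl group at this place could test.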